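Swapping the amine for an ether on compound 2

A few compounds are considered here, and "the series" means these few. Any claim that something is new, unique, unknown or untested is made for them only; others in the source may bear on it.

Measured so far:
- compound 1, `CC(C)Nc1ccc(-c2ccn3c(CC4CC4)nnc3c2C(F)(F)F)cc1F` — 93.3 nM
- compound 2, `CC(C)Nc1ccc(-c2ccn3c(CC4CC4)nnc3c2C(F)(F)F)cc1Cl` — 17.4 nM

Both compounds were tested in a functional assay on cells for positive allosteric modulation of metabotropic glutamate receptor 2 (Homo sapiens), read by scintillation counting and GTPgammaS binding, with a stated time of 30 min; on this read-out lower numbers stand for an effect already at smaller amounts and higher numbers for an effect only at larger amounts of compound. Compound 1 gives 93.3 nM. Within the data shown here, compound 2 gives 17.4 nM, the lowest of the two numbers; its only neighbour is compound 1, and the step of a 5.4-fold lower number from compound 1 to compound 2 (0.73 log units; beyond the scatter) separates them, with the structures differing only in a chloro in place of a fluoro on an aromatic carbon.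

Compound 3, `FC(F)(F)c1c(-c2ccc(OC3CCOCC3)c(Cl)c2)ccn2c(CC3CC3)nnc12`, keeps the chloro of compound 2 and changes a different part: (oxan-4-yl)oxy in place of isopropylamino on an aromatic carbon. Among the measured compounds shown here, no measured step touches this part of the molecule; the single step from compound 1 to compound 2 concerns the halogen alone and says nothing about exchanging the amine for the ether. The expectation therefore rests on compound 2 as the closest measured point, with wide uncertainty. A step of a 1.7-fold higher number from compound 2 to compound 3 (0.24 log units; within the scatter) is expected, which could fall within the scatter or go somewhat toward higher numbers. Compound 3 is estimated at 30 nM, with a range from 8 nM to 110 nM.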

Compound 3, half-maximal effective concentration: 38 nM
The estimate for compound 3 lay 1.3-fold (0.10 log units) below the measured number, within the range that was stated.
By their numbers in this assay, from the lowest: compound 2; then compound 3; then compound 1.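

In this assay, putting (oxan-4-yl)oxy in place of isopropylamino gives a 2.2-fold higher number from compound 2 to compound 3 (0.34 log units; beyond the scatter), a modest step that lies beyond the scatter. This shows that the place ortho to a chloro group and para to a large group is not tied to isopropylamino: a bigger group with a six-membered non-aromatic ring and no hydrogen-bond donor still gives a number of the same general order, though somewhat higher. Nothing measured here accounts for this step.

The exchange alters the atom attached to the aromatic ring and the group beyond that atom at once, and the compounds shown cannot say which of these two changes carries the step; isopropoxy or an oxan-4-ylamino group would each change only one of them. Also open, on these data alone, is whether the step from fluoro to chloro seen with the amine, a 5.4-fold lower number from compound 1 to compound 2 (0.73 log units; beyond the scatter), would hold in the same way with the ether in place.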